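This account rests on a few compounds, and the source may have more. Where it says the series, first, only, none or still open, it means among the compounds named here.

Measured in a functional assay on ACHN cells (Homo sapiens) for inhibition, read by sulforhodamine B assay, with a stated time of 48 h; on this read-out higher numbers stand for weaker inhibition of growth and lower numbers for stronger inhibition of growth:

Compound 1 `O=C(Nc1cccc(-n2cc(-c3ccncc3)c(-c3ccc(Cl)c(O)c3)n2)c1)Nc1cccc(C(F)(F)F)c1` gives 1290 nM
Compound 2 `COc1cc(-c2nn(-c3cccc(NC(=O)Nc4cc(C(F)(F)F)cc(C(F)(F)F)c4)c3)cc2-c2ccncc2)ccc1Cl` gives 491 nM
Compound 3 `COc1cc(-c2nn(-c3cccc(NC(=O)c4cccc(C(F)(F)F)c4)c3)cc2-c2ccncc2)ccc1Cl` gives 1890 nM

Compound 3 lies within the scatter of compound 1, while compound 2 has a lower number, beyond the scatter. Compound 4 `COc1cc(-c2nn(-c3cccc(NC(=O)c4ccc(Cl)c(C(F)(F)F)c4)c3)cc2-c2ccncc2)ccc1Cl` differs from compound 3 by chloro in place of hydrogen on an aromatic carbon, with chloro in place of hydrogen on an aromatic carbon, ortho to a trifluoromethyl group and para to a large group. Among the compounds with values here, no measured pair isolates this change. Within the data shown here, compound 2, the only measured compound with two trifluoromethyl groups, gives 491 nM, but it differs from compound 3 in more than one place. Only a small move towards stronger inhibition of growth in this assay is therefore expected, possibly none beyond the scatter. The expected step is a 1.9-fold lower number from compound 3 to compound 4 (0.28 log units; within the scatter). The estimated value for compound 4 is 1000 nM, with an expected range of 400 nM to 2500 nM.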

Compound 4, concentration for 50% growth inhibition: 2730 nM
Beside the measured number, compound 4's estimate is 2.7-fold (0.44 log units) below it; the whole stated range lies below it.
By their numbers in this assay, from the lowest: compound 2; then compounds 1, 3 and 4 (each within the scatter of the next, the first and the last beyond it).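

Chloro in place of hydrogen on this aromatic carbon, ortho to a trifluoromethyl group and para to a large group, gives a 1.4-fold higher number from compound 3 to compound 4 (0.16 log units; within the scatter) in this assay and so makes no change that can be told from the scatter. This position therefore carries a chloro group without a readable loss or gain in this read-out. Nothing available explains this result.

As far as these compounds go, whether an amine or a carboxylic acid at this position would move the number beyond the scatter stays open. Also open, from the compounds shown here alone, is how chloro would read here on compound 2.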